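The source may report more compounds than this note shows. Statements on the series, on what has been measured and on what is new or still open speak of the compounds shown alone.

Compound 1 `O=C(CCc1cccc2c1B(O)OC2)Nc1ccccc1` is the strongest of the three compounds measured in a functional assay on MDA-MB-231 cells (Homo sapiens) for antiproliferative activity, read by MTT assay, with a stated time of 72 h (a lower number here means a stronger inhibitor, a higher number a weaker inhibitor), where compound 1 gives 230 nM. Compound 3 `COc1ccccc1NC(=O)CCc1cccc2c1B(O)OC2` gives 930 nM, and compound 2 `CC(C)(C)OC(=O)Nc1ccc(NC(=O)CCc2cccc3c2B(O)OC3)cc1` gives 29000 nM. Both measured steps bear on the question: a 4.0-fold higher number from compound 1 to compound 3 (0.61 log units; beyond the scatter) and a 130-fold higher number from compound 1 to compound 2 (2.10 log units; beyond the scatter), so each addition to the ring that carries the amide nitrogen weakened inhibition, the bulkier one far more. Compound 4 `COc1cc(OC)cc(-c2cccc(NC(=O)CCc3cccc4c3B(O)OC4)c2)c1` differs from compound 1 by 3,5-dimethoxyphenyl in place of hydrogen on an aromatic carbon, a sizeable group placed meta to a large group. A weakening step in this assay is therefore expected, with an 11-fold higher number from compound 1 to compound 4 (1.04 log units; beyond the scatter), smaller than for compound 2 but clearly larger than for compound 3. Compound 4 is estimated at 2500 nM, within a range of 600 nM to 10000 nM.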

Compound 4, half-maximal inhibitory concentration: 40 nM
The estimate for compound 4 lay 63-fold (1.80 log units) above the measured number; measured number outside the range, below it.
By their numbers in this assay, from the lowest: compound 4; then compound 1; then compound 3; then compound 2.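

The ring that carries the amide nitrogen can take an addition and still gain strength: in this assay 3,5-dimethoxyphenyl, meta to a large group, gives a 5.8-fold lower number from compound 1 to compound 4 (0.76 log units; beyond the scatter) while both earlier additions weakened inhibition. Added bulk therefore does not always cost activity on this ring, as compound 2 alone might have suggested. Nothing measured here explains the gain.

On these data alone, it remains open whether the two methoxy groups matter or a plain phenyl would do as well. An amine or a carboxylic acid on the added ring is also untested among these compounds.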